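Cytotoxicity notes on a fluoro-for-methyl change

This account rests on a few compounds, and the source may have more. Where it says the series, first, only, none or still open, it means among the compounds named here.

Compound 1 `CONC(=S)N/N=C1\C(=O)N(CN(C)C)c2ccc(F)cc21` and compound 2 `CONC(=S)N/N=C1\C(=O)N(CN(C)C)c2ccc(C)cc21` share a small core; compound 3 `CCn1cc(C(=O)O)c(=O)c2cc(F)c(N3CCN(CN4C(=O)/C(=N\NC(=S)NOC)c5cc(C)ccc54)CC3)cc21` and compound 4 `CCn1cc(C(=O)O)c(=O)c2cc(F)c(N3CCN(CN4C(=O)/C(=N\NC(=S)NOC)c5cc(F)ccc54)CC3)cc21` share a larger one, and the difference between the two cores is not broken down here. In an ADME assay on MT4 cells (Homo sapiens) for cytotoxicity, read by spectrophotometry, with a stated time of 5 days (a lower number here means that less compound is tolerated, a higher number that more compound is tolerated), compound 2 gives 622000 nM, and compound 1 gives 560000 nM; the change fluoro in place of methyl on an aromatic carbon gives the step of a 1.1-fold lower number from compound 2 to compound 1 (0.05 log units; within the scatter). In this assay compound 3 gives 238000 nM, the lowest of the three measured numbers. Compound 4 carries the same change, (fluoro in place of methyl on an aromatic carbon), at the same kind of place on its larger core. The expected step is a 1.1-fold lower number from compound 3 to compound 4 (0.03 log units; within the scatter) because the same change on the smaller core gave a 1.1-fold lower number from compound 2 to compound 1 (0.05 log units; within the scatter). Compound 4 in this assay is estimated at 220000 nM, with a range from 120000 nM to 400000 nM.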

Compound 4, half-maximal cytotoxic concentration: 144000 nM
Estimate against measurement, compound 4: 1.5-fold (0.18 log units) above; measured number inside the range.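

In this assay, fluoro in place of methyl on an aromatic carbon gives a 1.7-fold lower number from compound 3 to compound 4 (0.22 log units; within the scatter). Set beside the step on the smaller core, the change carries across the two cores without a difference beyond the scatter: the same change on two cores in this assay, a 1.1-fold lower number (0.05 log units; within the scatter) from compound 2 to compound 1 and a 1.7-fold lower number (0.22 log units; within the scatter) from compound 3 to compound 4, 1.5-fold (0.17 log units) apart, within the scatter of two such steps. This shows agreement for two matched pairs only, with neither step beyond the scatter, so it does not show that the change would behave the same way on other cores, nor does it explain the size of either step.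

The compounds shown leave open how other groups on the same aromatic carbon, such as chloro, methoxy or a nitrile, would compare on either core. They also leave open whether any such group would give a step beyond the scatter.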